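A chloro for a methyl in a small series

This account rests on a few compounds, and the source may have more. Where it says the series, first, only, none or still open, it means among the compounds named here.

Of the compounds shown here, three sharing one core have been measured so far in an ADME assay on HepG2 cells (Homo sapiens) for cytotoxicity, read by fluorescence and resazurin assay, with a stated time of 24 h (on this read-out higher numbers stand for lower toxicity in this test and lower numbers for higher toxicity in this test), and give these numbers. Compound 1 (`COC(=O)c1ccc(-c2nnc(SC3=CS(=O)(=O)c4ccccc43)o2)cc1`) reads 18000 nM there, compound 2 (`O=S1(=O)C=C(Sc2nnc(-c3ccccn3)o2)c2ccccc21`) reads 24000 nM and compound 3 (`Cc1ccc(-c2nnc(SC3=CS(=O)(=O)c4ccccc43)o2)cc1`) reads 31000 nM in the same test. Compound 3 lies within the scatter of both others, so the three numbers carry no ranking.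

The change to compound 4 (`O=S1(=O)C=C(Sc2nnc(-c3ccc(Cl)cc3)o2)c2ccccc21`) is chloro in place of methyl on an aromatic carbon, para to a large group (chloro in place of methyl on an aromatic carbon). For the measured compounds named here, two measured steps bear on it. One is a 1.7-fold higher number from compound 1 to compound 3 (0.24 log units; within the scatter) with methyl in place of methoxycarbonyl on an aromatic carbon, and the other is a 1.3-fold higher number from compound 2 to compound 3 (0.11 log units; within the scatter) with 4-methylphenyl in place of pyridin-2-yl on an aromatic carbon. Going by the values given here, neither step leaves the scatter, neither gives a direction, and no measured compound carries chloro. No step beyond the scatter is therefore expected in this assay for this exchange. The expected step is a 1.2-fold lower number from compound 3 to compound 4 (0.09 log units; within the scatter) and it is estimated to stay within the scatter. Compound 4 is expected at 25000 nM within an estimated range of 13000 nM to 48000 nM in this test.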

Compound 4, half-maximal cytotoxic concentration: 22000 nM
Estimate against measurement, compound 4: 1.1-fold (0.06 log units) above; measured number inside the range.
By their numbers in this assay, from the lowest: compounds 1, 4, 2 and 3 (each within the scatter of the next).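

In this assay the exchange of 4-methylphenyl for 4-chlorophenyl, chloro in place of methyl on an aromatic carbon, para to a large group, shows a 1.4-fold lower number from compound 3 to compound 4 (0.15 log units; within the scatter) and so gives a direct reading of this change that stays inside the scatter. The other two steps into compound 4 stay inside it as well, a 1.1-fold lower number from compound 2 to compound 4 (0.04 log units; within the scatter) with 4-chlorophenyl in place of pyridin-2-yl and a 1.2-fold higher number from compound 1 to compound 4 (0.09 log units; within the scatter) with chloro in place of methoxycarbonyl, so the four compounds cannot be ranked, and none of them goes against this. Nothing measured here accounts for how close these numbers lie.

A carboxylic acid, a primary amine or a butyl chain in the place of chloro does not appear among these compounds, and whether any such group would carry the number beyond the scatter stays open. Also open, on these data alone, is whether the exchange of methyl for chloro would read the same on a core other than the shared one.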